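The source may hold more compounds than are shown below. What is called first, only, known or untested is meant among the compounds shown, and "the series" means these compounds.

Measured so far in a functional assay on MDA-MB-231 cells (Homo sapiens) for inhibition, read by CCK-8 assay, with a stated time of 48 h; a higher number here means a weaker inhibitor of growth, a lower number a stronger inhibitor of growth:

Compound 1, `Cc1ccccc1Nc1nc(Nc2ccccc2)ncc1Cl`, gives only the assay limit of > 100000 nM and no number.
Compound 2, `Cc1ccccc1Nc1nc(Nc2ccc(N3CCNCC3)cn2)ncc1Cl`, gives 5060 nM.
Compound 3, `CN1CCN(c2ccc(Nc3ncc(Cl)c(NCc4ccc(C(F)(F)F)cc4)n3)nc2)CC1`, gives 19100 nM.

Of the two numbers that are not limits, compound 3 has the higher one, so among these it is the weaker inhibitor of growth; compound 2 sits at a lower number, and that gap lies beyond the usual scatter of such measurements. Compound 1 reaches only the limit, (the limit of > 100000 nM in this assay, at which 1 of the 3 values shown sits), so it gives no number to compare.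

The next compound to be measured is compound 4, `CN1CCN(c2ccc(Nc3ncc(Cl)c(Nc4ccc(C(C)(C)C)cc4)n3)nc2)CC1`. It differs from compound 3 in one place: 4-(tert-butyl)phenyl in place of 4-(trifluoromethyl)benzyl on a nitrogen on an aromatic ring. Within the data shown here, no step between two measured compounds matches this change, so the expectation rests on the values shown. Compound 2, which carries an aromatic ring directly on a nitrogen of the shared core, gives 5060 nM, a lower number than compound 3 by a margin beyond the scatter. For compound 4 the expected step is a 2.4-fold lower number from compound 3 to compound 4 (0.38 log units; beyond the scatter), a move toward a lower number in this assay. The estimate for compound 4 in this assay is therefore 8000 nM, with a range from 2500 nM to 25000 nM.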

Compound 4, concentration for 50% growth inhibition: 16200 nM
Beside the measured number, compound 4's estimate is 2.0-fold (0.31 log units) below it; the measured number falls inside the stated range.
By their numbers in this assay, from the lowest: compound 2; then compounds 4 and 3 (each within the scatter of the next). At a limit, above all of these: compound 1.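

Putting 4-(tert-butyl)phenyl in place of 4-(trifluoromethyl)benzyl on a nitrogen on an aromatic ring gives, in this assay, a 1.2-fold lower number from compound 3 to compound 4 (0.07 log units; within the scatter). So this position accepts two quite different groups, a benzyl and a phenyl, each carrying its own group on the ring, without a difference that can be told apart from repeat-to-repeat variation, and an aromatic ring set directly on this nitrogen does not by itself bring a clear gain here. Nothing measured among the compounds shown explains why these two groups read alike.

As far as these compounds go, the ring's attachment and the group on the ring change together in this one step, so the contribution of each stays unknown: the two could matter little, or they could pull in opposite directions and cancel. Also open, from the compounds shown here alone, is whether an amine or a carboxylic acid on that ring, or a longer chain in place of the benzyl, would move the number beyond the scatter.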